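The source may hold more compounds than are shown below. What is called first, only, known or untested is meant among the compounds shown, and "the series" means these compounds.

Series notes. Compound 1 `COc1ccc(Nc2nc(NC3CCCC3)c3ccccc3n2)cc1` in a functional assay on MV4-11 cells (Homo sapiens) for antiproliferative activity, read by MTT assay (on this read-out higher numbers stand for weaker inhibition of growth and lower numbers for stronger inhibition of growth), gives 4910 nM; compound 2 `CCCNc1nc(Nc2ccc(OC)cc2)nc2ccccc12` in this assay gives 5880 nM, and the step of a 1.2-fold higher number from compound 1 to compound 2 (0.08 log units; within the scatter) is within the scatter. Compound 3 `CNc1nc(Nc2ccc(OC)cc2)nc2ccccc12` differs from compound 1 by methyl in place of cyclopentyl on a nitrogen on an aromatic ring. Going by the values given here, the only comparable step is a 1.2-fold higher number from compound 1 to compound 2 (0.08 log units; within the scatter), where the replacement at the same nitrogen did not move the number beyond the scatter. Compound 3 is therefore expected to stay close to compound 1, with at most a small rise; the expected step is a 1.3-fold higher number from compound 1 to compound 3 (0.12 log units; within the scatter). The estimate for compound 3 is 6500 nM, in the range 2500 nM to 17000 nM.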

Compound 3, concentration for 50% growth inhibition: 3070 nM
Compound 3: the middle estimate sits 2.1-fold (0.33 log units) above what was measured, and the stated range covers the measured number.
By their numbers in this assay, from the lowest: compounds 3, 1 and 2 (each within the scatter of the next).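

In this assay, methyl in place of cyclopentyl on this nitrogen gives a 1.6-fold lower number from compound 1 to compound 3 (0.20 log units; within the scatter) and, against the propyl compound, a 1.9-fold lower number from compound 2 to compound 3 (0.28 log units; within the scatter) within the scatter. Even with five carbons and their ring reduced to a single carbon, the three compounds shown remain within the scatter of one another, which the propyl step alone could not show. No measurement bearing on a cause is available.

Open, as far as these compounds go, is whether a carboxylic acid, an amine-bearing chain or a phenyl ring on this nitrogen would move the number beyond the scatter.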